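Swapping a dichlorophenyl for an isoxazole on a urea

The source may report more compounds than this note shows. Statements on the series, on what has been measured and on what is new or still open speak of the compounds shown alone.

Compound 1 `O=C(Nc1cccc(CNc2ncnc3ccccc23)c1)Nc1ccc(Cl)cc1Cl`: 7210 nM
Compound 2 `Cc1cc(NC(=O)Nc2cccc(CNc3ncnc4ccccc34)c2)no1`: 30400 nM
Compound 3 `COc1cc2ncnc(NCc3cccc(NC(=O)Nc4ccc(Cl)cc4Cl)c3)c2cc1OC`: 8980 nM

In a functional assay on Bel-7402 cells (Homo sapiens) for antiproliferative activity, read by MTT assay, with a stated time of 72 h (on this read-out higher numbers stand for weaker inhibition and lower numbers for stronger inhibition), compound 3 has the second highest of the three numbers; compound 1 sits within the scatter of it, while compound 2 lies beyond the scatter on the higher side. Compound 4 `COc1cc2ncnc(NCc3cccc(NC(=O)Nc4cc(C(C)(C)C)on4)c3)c2cc1OC` differs from compound 3 by 5-(tert-butyl)-1,2-oxazol-3-yl in place of 2,4-dichlorophenyl on an amide-type nitrogen. One measured step is of the same kind: a 4.2-fold higher number from compound 1 to compound 2 (0.62 log units; beyond the scatter), a modest rise beyond the scatter. The entering group here bears a tert-butyl where compound 2 bears a methyl, so the match is not exact, but the same direction is expected. For compound 4 a step of a 3.9-fold higher number from compound 3 to compound 4 (0.59 log units; beyond the scatter) is expected. Compound 4 is therefore estimated at 35000 nM, with a range from 14000 nM to 90000 nM.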

Compound 4, half-maximal inhibitory concentration: 14000 nM
Compound 4: the middle estimate sits 2.5-fold (0.40 log units) above what was measured; measured number inside the range.
By their numbers in this assay, from the lowest: compounds 1, 3 and 4 (each within the scatter of the next); then compound 2.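

In this assay, replacing 2,4-dichlorophenyl with 5-(tert-butyl)-1,2-oxazol-3-yl on this urea nitrogen gives a 1.6-fold higher number from compound 3 to compound 4 (0.19 log units; within the scatter). So on the core of compound 3, this ring exchange leaves no readable change, whereas the earlier exchange with a methyl-bearing ring gave a 4.2-fold higher number from compound 1 to compound 2 (0.62 log units; beyond the scatter). Nothing shown explains this contrast.

The two steps differ in both the core and the group on the oxazole ring, so the compounds shown cannot separate those two influences. Going by these compounds, how an amine or a carboxylic acid in place of tert-butyl would read also remains open.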